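Extending an Ethoxy to Propoxy on a Shared Core

A few compounds are considered here, and "the series" means these few. Any claim that something is new, unique, unknown or untested is made for them only; others in the source may bear on it.

The series rests on one shared core carrying an acid-bearing side. Compound 1 `Cc1cc(OCC(=O)N(C)C)cc(C)c1-c1cccc(COc2ccc(OCC(=O)O)c(F)c2)c1` and compound 2 `Cc1cc(OCCCS(C)(=O)=O)cc(C)c1-c1cccc(COc2ccc(N(CC(=O)O)C(=O)c3ccoc3)cc2)c1` belong to it, yet for compound 1 the outcome in a functional assay on CHO cells for agonist activity at Free fatty acid receptor 1 (Homo sapiens), read by FLIPR and calcium flux (on this read-out lower numbers stand for an effect already at smaller amounts and higher numbers for an effect only at larger amounts of compound), is "not determined" (no result reported), and for compound 2 it is likewise "not determined" (no result reported). Among the measured compounds shown here, the single number comes from compound 3 `CCOc1cc(C)c(-c2cccc(COc3ccc(OCC(=O)O)c(F)c3)c2)c(C)c1`: in this assay compound 3 gives 65.9 nM, and with no second number beside it, compound 3 stands alone as the only reference point.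

Compound 4 `CCCOc1cc(C)c(-c2cccc(COc3ccc(OCC(=O)O)c(F)c3)c2)c(C)c1` differs from compound 3 by methyl in place of hydrogen on a saturated chain carbon, two bonds along the chain from an oxygen on an aromatic ring. For the measured compounds named here, no step between measured compounds is available to gauge such a change, so the expectation rests on compound 3 alone. Since the change adds a single carbon to the chain, the step of a 1.3-fold lower number from compound 3 to compound 4 (0.12 log units; within the scatter) is expected to be small and likely within the usual scatter, if anything leaning toward an effect at slightly smaller amounts. For compound 4 the estimate in this assay is 50 nM, with a plausible range from 20 nM to 150 nM.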

Compound 4, half-maximal effective concentration: 106 nM
Compound 4: the middle estimate sits 2.1-fold (0.33 log units) below what was measured, and the stated range covers the measured number.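

In this assay, among the compounds shown here, the ethoxy to propoxy change gives the first readable step at this position, a 1.6-fold higher number from compound 3 to compound 4 (0.21 log units; within the scatter), and the two compounds cannot be told apart on this read-out. The series thus shows that methyl in place of hydrogen on this saturated chain carbon leaves the agonist reading within repeat-measurement noise, which a single reference value could not show. No supporting measurement bears on why the reading behaves this way.

This is one step of a single carbon, so it sets no trend along the chain. From the compounds shown here alone, whether a longer chain such as butoxy, a branched chain such as isopropoxy, or a chain ending in an amine or a carboxylic acid would read the same at this place stays open.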